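Bromo for Hydrogen on the Anilide Ring of Compound 1

A few compounds are considered here, and "the series" means these few. Any claim that something is new, unique, unknown or untested is made for them only; others in the source may bear on it.

Compound 1 `O=C(COc1ccc2cc(/C=C3/SC(=O)NC3=O)ccc2c1)Nc1ccccc1` is one of three compounds on a shared core tested in an assay on isolated protein for inhibition of histone deacetylase 4 (Homo sapiens), with a stated time of 1 h; on this read-out higher numbers stand for weaker inhibition and lower numbers for stronger inhibition. Compound 1 gives 2100 nM, the highest of the three numbers. Compound 2 `O=C(COc1ccc2cc(/C=C3/SC(=O)NC3=O)ccc2c1)Nc1ccc(F)cc1` gives 1600 nM in this assay, and compound 3 `Cc1cccc(NC(=O)COc2ccc3cc(/C=C4/SC(=O)NC4=O)ccc3c2)n1` gives 1100 nM. Both the step of a 1.3-fold lower number from compound 1 to compound 2 (0.12 log units; within the scatter) and the step of a 1.9-fold lower number from compound 1 to compound 3 (0.28 log units; within the scatter) lie within the scatter, so compound 1 is not separated from either on these numbers.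

Compound 4 `O=C(COc1ccc2cc(/C=C3/SC(=O)NC3=O)ccc2c1)Nc1ccc(Br)cc1` has not yet been measured. It differs from compound 1 in one place: bromo in place of hydrogen on an aromatic carbon. Among the measured compounds shown here, of the measured steps, the one from compound 1 to compound 2 bears most directly on this change. That step too introduces a halogen, and it gave a 1.3-fold lower number from compound 1 to compound 2 (0.12 log units; within the scatter). The step to compound 3 alters another part of the molecule and offers little guidance. The expected step of a 1.4-fold lower number from compound 1 to compound 4 (0.15 log units; within the scatter) is therefore small, leaning if anything toward a lower number, and not clearly beyond the scatter. Compound 4 is estimated at 1500 nM in this assay, within a range from 700 nM to 3200 nM.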

Compound 4, half-maximal inhibitory concentration: 2900 nM
Compound 4: middle estimate off by 1.9-fold (0.29 log units), on the low side; the range from low to high includes it.
By their numbers in this assay, from the lowest: compounds 3, 2, 1 and 4 (each within the scatter of the next, the first and the last beyond it).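

In this assay, bromo on this aromatic carbon, para to a large group, does not separate compound 4 from its closest relatives: the change from hydrogen gives a 1.4-fold higher number from compound 1 to compound 4 (0.14 log units; within the scatter), and the change from fluoro gives a 1.8-fold higher number from compound 2 to compound 4 (0.26 log units; within the scatter). The one step here that clears the scatter is a 2.6-fold higher number from compound 3 to compound 4 (0.42 log units; beyond the scatter), a modest gap and the first such separation among these compounds, and it replaces the whole group on the amide-type nitrogen rather than a single atom. No measurement at hand accounts for any of these numbers.

The compounds shown leave open whether an amine, a methoxy group or a carboxylic acid on this same carbon would move the number beyond the scatter from compound 1. They also leave open whether a pyridin-2-yl group without the methyl would stay level with the 6-methylpyridin-2-yl group of compound 3.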